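This account rests on a few compounds, and the source may have more. Where it says the series, first, only, none or still open, it means among the compounds named here.

Measured in an ADME assay on CCRF-CEM cells (Homo sapiens) for cytotoxicity, read by cell counting; on this read-out higher numbers stand for lower toxicity in this test and lower numbers for higher toxicity in this test:
- Compound 1 `Cc1cc(C)cc(S(=O)(=O)c2c(C(=O)NCc3ccccc3)[nH]c3ccc(Br)cc23)c1`: 172000 nM
- Compound 2 `Cc1cc(C)cc(S(=O)(=O)c2c(C(=O)NCc3ccccc3)[nH]c3ccc([N+](=O)[O-])cc23)c1`: 8000 nM
- Compound 3 `Cc1cc(C)cc(S(=O)(=O)c2c(C(=O)NCCOc3ccccc3)[nH]c3ccc([N+](=O)[O-])cc23)c1`: > 500000 nM, which is a limit of the assay

Of the two values that are exact numbers, compound 2 has the lower, 8000 nM, so it is the most toxic of the three in this assay. Compound 4 `Cc1cc(C)cc(S(=O)(=O)c2c(C(=O)NCc3ccccc3)[nH]c3ccc(Cl)cc23)c1` differs from it by one change, chloro in place of nitro on an aromatic carbon.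

Going by the values given here, the closest precedent is nitro in place of bromo on an aromatic carbon, which gave a 22-fold lower number from compound 1 to compound 2 (1.33 log units; beyond the scatter). The other measured step, phenoxymethyl in place of phenyl on a saturated chain carbon bound to an amide-type nitrogen, gave an at least 62-fold higher number from compound 2 to compound 3 (1.79 log units; beyond the scatter). It is also large, but it lies elsewhere in the molecule and bears little on this change.

Compound 4 gives up the nitro and carries a halogen like compound 1, so a large move to a higher number is expected, of similar size to the bromo step but reversed. The expected change is a 15-fold higher number from compound 2 to compound 4 (1.18 log units; beyond the scatter). Compound 4 is estimated at 120000 nM, with an expected range of 35000 nM to 400000 nM.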

Compound 4, half-maximal cytotoxic concentration: 244000 nM
For compound 4 the middle estimate is 2.0-fold (0.31 log units) below the measured one, and the stated range covers the measured number.
By their numbers in this assay, from the lowest: compound 2; then compounds 1 and 4 (each within the scatter of the next). At a limit, above all of these: compound 3.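

In this assay, the comparison of the two halogens at this position gives a 1.4-fold higher number from compound 1 to compound 4 (0.15 log units; within the scatter) and so chloro and bromo read alike on this aromatic carbon. Against that pair, nitro stands apart, with a 31-fold higher number from compound 2 to compound 4 (1.48 log units; beyond the scatter) confirming what the single step from bromo could not show alone: the low number of compound 2 is set against two halogens, not one. Nothing measured here explains why the nitro compound differs from the halogen compounds.

Going by these compounds, it remains open whether the low number belongs to nitro alone or would also appear with another group at this position, such as an amine or a nitrile. On these data alone, it is also open whether chloro or bromo would keep these numbers on the phenoxymethyl chain of compound 3.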